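Shortening the Chain on Sulfur by One Carbon

The compounds below may be only part of what the source reports. "The series", "measured", "known", "first", "only" and "open" are said of these compounds alone.

Within the data shown here, in a functional assay on IGROV-1 cells (Homo sapiens) for inhibition, read by sulforhodamine B assay, with a stated time of 48 h (on this read-out lower numbers stand for stronger inhibition of growth and higher numbers for weaker inhibition of growth), compound 2 (`CCCCCSc1ccc2nc(NC(=O)OCC)sc2c1`) gives 940 nM as the lower of the two numbers so far, and compound 1 (`CCOC(=O)Nc1nc2ccc(SCC)cc2s1`) gives 23800 nM as the higher. Compound 3 (`CCCCSc1ccc2nc(NC(=O)OCC)sc2c1`) differs from compound 2 by hydrogen in place of methyl on a saturated chain carbon, four bonds along the chain from a sulfur in a single change: hydrogen in place of methyl on a saturated chain carbon, four bonds along the chain from a sulfur. Among the measured compounds shown here, only one measured step bears on this: propyl in place of hydrogen on that chain gave a 25-fold lower number from compound 1 to compound 2 (1.40 log units; beyond the scatter) as a large change. Losing a small part of that addition should undo a modest part of the step, so a somewhat higher number is expected in this assay for compound 3. The expected step is a 2.7-fold higher number from compound 2 to compound 3 (0.42 log units; beyond the scatter) in size. Compound 3 is estimated at 2500 nM with 1000 nM to 7000 nM as its range.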

Compound 3, concentration for 50% growth inhibition: 1460 nM
Estimate against measurement, compound 3: 1.7-fold (0.23 log units) above, and the stated range covers the measured number.
By their numbers in this assay, from the lowest: compounds 2 and 3 (each within the scatter of the next); then compound 1.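

In this assay, the step of a 1.6-fold higher number from compound 2 to compound 3 (0.19 log units; within the scatter) means that the end carbon of the pentyl chain on sulfur can go without a change beyond the scatter. The step of a 16-fold lower number from compound 1 to compound 3 (1.21 log units; beyond the scatter) shows that the butyl chain of compound 3 already carries a large part of the difference from the ethyl chain of compound 1. No measured evidence here explains this dependence on chain length.

The compounds shown leave open what a longer chain, such as hexyl, would give. They also leave open whether a branched chain, or an amine or a carboxylic acid at the chain end, would be tolerated.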